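The source may report more compounds than this note shows. Statements on the series, on what has been measured and on what is new or still open speak of the compounds shown alone.

Measured compounds:
compound 1 `CN1CCC(n2cc(S(=O)(=O)c3cccc(Cl)c3)c3cccnc32)C1`, 142 nM
compound 2 `CCN1CCC(n2cc(S(=O)(=O)c3cccc(Cl)c3)c3cccnc32)C1`, 120 nM
compound 3 `CN1CCCC(n2cc(S(=O)(=O)c3ccc(Cl)cc3)c3cccnc32)C1`, 28 nM

In a functional assay on HeLa cells for antagonist activity at 5-hydroxytryptamine receptor 6 (Homo sapiens), read by cAMP accumulation and immunoassay (on this read-out higher numbers stand for weaker inhibition and lower numbers for stronger inhibition), compound 1 gives 142 nM and compound 2 gives 120 nM. The two differ by methyl in place of hydrogen on a saturated chain carbon bound to an amine nitrogen in a ring, and that change made a 1.2-fold lower number from compound 1 to compound 2 (0.07 log units; within the scatter). Compound 3 stands apart from both: it gives 28 nM in this assay, and its values against compound 2 and compound 1 lie beyond the scatter, so among the three measured compounds it has the lowest number. How the core of compound 3 differs from the core of compound 1 is not broken down here.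

Compound 4 `CCN1CCCC(n2cc(S(=O)(=O)c3ccc(Cl)cc3)c3cccnc32)C1` has not yet been measured. It differs from compound 3 by methyl in place of hydrogen on a saturated chain carbon bound to an amine nitrogen in a ring, the same change, in the same place, that was made from compound 1 to compound 2. Because that earlier step was a 1.2-fold lower number from compound 1 to compound 2 (0.07 log units; within the scatter), the step from compound 3 to compound 4 in this assay is expected to be about a 1.2-fold lower number from compound 3 to compound 4 (0.07 log units; within the scatter). On that basis compound 4 is estimated to give 24 nM in this assay, with a range from 10 nM to 60 nM.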

Compound 4, half-maximal inhibitory concentration: 70 nM
The estimate for compound 4 lay 2.9-fold (0.46 log units) below the measured number, and the stated range ends below it.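

The change from methyl to ethyl, as 1-methylpiperidin-3-yl became 1-ethylpiperidin-3-yl, gave a 2.5-fold higher number from compound 3 to compound 4 (0.40 log units; beyond the scatter) in this assay. Set beside the earlier step, this shows that the change did not carry over with the same result from one core to the other: the same change on two cores in this assay, a 1.2-fold lower number (0.07 log units; within the scatter) from compound 1 to compound 2 and a 2.5-fold higher number (0.40 log units; beyond the scatter) from compound 3 to compound 4, 3.0-fold (0.47 log units) apart, beyond the scatter of two such steps. Resting on only two pairs, the comparison shows that the outcome of this change differed between these two cores, but it does not show which feature of the cores accounts for the difference or how the change would behave on any other core in the series.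

The compounds shown leave open whether a longer chain, such as propyl, on the ring amine nitrogen of the core of compound 3 would move the number further in the same direction. They also leave open how a branched group such as isopropyl, or a hydrogen, at that nitrogen would read out on each of the two cores.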